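Methyl on the furan ring: a small step from compound 1

The source may hold more compounds than are shown below. What is called first, only, known or untested is meant among the compounds shown, and "the series" means these compounds.

Measured so far:
compound 1, `O=C(Cn1c(-c2ccco2)nc2ccccc21)N/N=C/c1ccccc1Cl`, 26100 nM
compound 2, `CCOC(=O)CSc1nnc(Cn2c(-c3ccco3)nc3ccccc32)s1`, 28500 nM

Both numbers come from a functional assay on MCF7 cells (Homo sapiens) for cytotoxicity, read by sulforhodamine B assay, with a stated time of 48 h; on this read-out lower numbers stand for stronger inhibition and higher numbers for weaker inhibition. In this assay compound 1 gives 26100 nM, and compound 2 gives 28500 nM. The two values lie within the usual scatter of each other, so the data do not separate them; compound 1 simply has the smaller of two closely spaced numbers.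

Compound 3, `Cc1ccc(-c2nc3ccccc3n2CC(=O)N/N=C/c2ccccc2Cl)o1`, has not been measured. It differs from compound 1 by methyl in place of hydrogen on an aromatic carbon: a hydrogen on the furan ring, next to the ring oxygen, is exchanged for a methyl. Going by the values given here, no measured pair shows what such a change does here, so the expected step from compound 1 to compound 3 is small, none beyond the scatter, and its estimated size is a 1.2-fold lower number from compound 1 to compound 3 (0.07 log units; within the scatter). Compound 3 is therefore expected to give 22000 nM, in the range 10000 nM to 50000 nM.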

Compound 3, half-maximal inhibitory concentration: 21300 nM
Estimate against measurement, compound 3: 1.0-fold (0.01 log units) above; the range from low to high includes it.
By their numbers in this assay, from the lowest: compounds 3, 1 and 2 (each within the scatter of the next).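

Going by these compounds alone, this is the first pair here that differs in only one place, so it gives the first direct view of the furan ring. In this assay, the change from furan-2-yl to 5-methylfuran-2-yl gives a 1.2-fold lower number from compound 1 to compound 3 (0.09 log units; within the scatter), so the data do not separate the two compounds and a methyl next to the ring oxygen brings no measurable gain or loss. Nothing available explains why the methyl has so little effect on the number.

From the compounds shown here alone, whether a longer chain such as propyl, or an amine or a carboxylic acid, at this same position would move the number beyond the scatter remains open. Going by these compounds, it is also open whether the same methyl would give a similarly small step on compound 2 , which carries a different group on the shared core.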